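Swapping the Aryl Group on the Chain Carbon

The source may report more compounds than this note shows. Statements on the series, on what has been measured and on what is new or still open speak of the compounds shown alone.

Measured compounds and their values:
- Compound 1, `O=C(/C(=C\c1ccc(Cl)cc1Cl)Sc1ccc(Br)cc1)c1ccc(Br)cc1`: 1000 nM
- Compound 2, `O=C(/C(=C\c1ccc(F)cc1Cl)Sc1ccc(Br)cc1)c1ccc(Br)cc1`: 1000 nM
- Compound 3, `Nc1c(Br)cc(Br)cc1/C=C(/Sc1ccc(Br)cc1)C(=O)c1ccc(Br)cc1`: > 100000 nM

All three share one core and differ only in the aromatic ring attached to the double-bonded chain carbon. In a functional assay on DU-145 cells (Homo sapiens) for inhibition, read by trypan blue exclusion, with a stated time of 96 h (a higher number here means a weaker inhibitor of growth, a lower number a stronger inhibitor of growth), compound 1 and compound 2 give the same value within the scatter, as no change at the digits printed from compound 1 to compound 2 (within the scatter) shows. Compound 3 stands apart: its result is only a limit of the assay, (the limit of > 100000 nM in this assay, at which 1 of the 3 values shown sits), not a number. The steps of an at least 100-fold higher number from compound 1 to compound 3 (2.00 log units; beyond the scatter) and an at least 100-fold higher number from compound 2 to compound 3 (2.00 log units; beyond the scatter) are therefore both large.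

Compound 4, `O=C(/C(=C\c1ccc(Br)c(O)c1)Sc1ccc(Br)cc1)c1ccc(Br)cc1`, has not yet been measured. It differs from compound 3 in one place: 4-bromo-3-hydroxyphenyl in place of 2-amino-3,5-dibromophenyl on a double-bonded chain carbon bound to a double-bonded chain carbon. This removes the group that carried the large loss seen in those two steps, and brings in a halogenated ring bearing a hydroxy group, closer in kind to the rings of compound 1 and compound 2. A large step toward a lower number is therefore expected, an at least 33-fold lower number from compound 3 to compound 4 (1.52 log units; beyond the scatter), though the hydroxy group is new to this series and leaves the size uncertain. Compound 4 is estimated at 3000 nM, within 500 nM to 50000 nM.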

Compound 4, concentration for 50% growth inhibition: 1000 nM
Compound 4: middle estimate off by 3.0-fold (0.48 log units), on the high side; the range from low to high includes it.
By their numbers in this assay, from the lowest: compounds 1, 2 and 4 (each within the scatter of the next). At a limit, above all of these: compound 3.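

Placing 4-bromo-3-hydroxyphenyl on the double-bonded chain carbon gives an at least 100-fold lower number from compound 3 to compound 4 (2.00 log units; beyond the scatter) in this assay, and this ring, which carries a hydroxy group, matches both rings bearing only halogens: no change at the digits printed from compound 2 to compound 4 (within the scatter) and no change at the digits printed from compound 1 to compound 4 (within the scatter). The ring of compound 4 has the same hydrogen-bond donor count as the ring of compound 3, so a donor on the ring does not by itself go with the loss seen for compound 3. The first step rests on a limit for compound 3, not on a number: the limit of > 100000 nM in this assay, at which 1 of the 4 values shown sits.

Going by these compounds, whether the amine or the pattern of bromines goes with the loss remains open, as both differ together here. Also open, on these data alone, is how this position responds to a ring bearing a methoxy group or a carboxylic acid.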